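This account rests on a few compounds, and the source may have more. Where it says the series, first, only, none or still open, it means among the compounds named here.

Compound 1 `O=c1[nH]c2ccccc2cc1-c1nc2cc(Br)ccc2[nH]1` in a functional assay on BEL-7404 cells for cytotoxicity against BEL-7404 tumor cell line (Homo sapiens), read by MTT assay, with a stated time of 48 h (a higher number here means a weaker inhibitor, a lower number a stronger inhibitor), gives 14500 nM. Compound 2 `Cc1ccc2[nH]c(=O)c(-c3nc4cc(Br)ccc4[nH]3)cc2c1` in this assay reaches only the limit of the assay, > 100000 nM. The step is an at least 6.8-fold higher number from compound 1 to compound 2 (0.83 log units; beyond the scatter). Because compound 2 sits at the limit (the limit of > 100000 nM in this assay, at which 1 of the 2 values shown sits), its true number is known only as lying beyond it. Compound 3 `COc1ccc2[nH]c(=O)c(-c3nc4cc(Br)ccc4[nH]3)cc2c1` differs from compound 2 by methoxy in place of methyl on an aromatic carbon. No measured step exchanges methyl for methoxy, so the shown numbers give no direction for it. The step of a number no higher from compound 2 to compound 3 (the limit leaves the size open) is expected to stay within the scatter. Compound 3 in this assay is expected near 100000 nM, between 20000 nM and 300000 nM, probably again only as a limit.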

Compound 3, half-maximal inhibitory concentration: > 100000 nM
Compound 3 ended at the assay's limit (the forecaster's own chance of this, stated with the estimate: 60%); the middle value lies on the limit itself.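

In this assay, replacing hydrogen with methoxy on this aromatic carbon gives an at least 6.8-fold higher number from compound 1 to compound 3 (0.83 log units; beyond the scatter). Methyl and methoxy, the two groups tried here, both go with a higher number than hydrogen, and the oxygen in methoxy brings no return towards the value of compound 1. Compound 2 and compound 3 cannot be ranked against each other, because both values are limits: the limit of > 100000 nM in this assay, at which 2 of the 3 values shown sit.

As far as these compounds go, how far beyond the limit each compound lies stays open. From the compounds shown here alone, it also stays open whether a fluorine atom or an amine on this carbon would keep the number close to that of compound 1.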